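N-Methylation of a piperidine amine in a cathepsin S series

The compounds below may be only part of what the source reports. "The series", "measured", "known", "first", "only" and "open" are said of these compounds alone.

Measured compounds:
compound 1, `CC(C)(C)OC(=O)N1CCN(CC(O)Cn2nc(-c3ccc(Cl)c(C#Cc4ccc(Cl)cc4)c3)c3c2CCN(S(C)(=O)=O)C3)CC1`, 150 nM
compound 2, `COC(=O)C1CCN(CC(O)Cn2nc(-c3ccc(Cl)c(C#Cc4ccc(Cl)cc4)c3)c3c2CCN(S(C)(=O)=O)C3)CC1`, 20 nM
compound 3, `CS(=O)(=O)N1CCc2c(c(-c3ccc(Cl)c(C#Cc4ccc(Cl)cc4)c3)nn2C[C@@H](O)CN2CCC(C3CCNCC3)CC2)C1`, 10 nM

All three were tested in an assay for inhibition of cathepsin S (Homo sapiens), read by FRET; on this read-out lower numbers stand for stronger inhibition and higher numbers for weaker inhibition. Compound 1 gives 150 nM, compound 2 gives 20 nM and compound 3 gives 10 nM. Going by the values given here, of the three numbers, the one for compound 3 is the lowest, but the number for compound 2 lies within the usual scatter of it, so the two cannot be told apart; only compound 1 stands clearly apart, with a number beyond the scatter above that of compound 3.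

Compound 4 is `CN1CCC(C2CCN(C[C@H](O)Cn3nc(-c4ccc(Cl)c(C#Cc5ccc(Cl)cc5)c4)c4c3CCN(S(C)(=O)=O)C4)CC2)CC1`. It differs from compound 3 in one place: methyl in place of hydrogen on an amine nitrogen in a ring. The change is a single carbon added to an amine nitrogen in the piperidin-4-yl group, far from the shared core. Among the compounds with values here, no pair of measured compounds shows this same exchange, so there is no measured step to lean on.

Given how small the change is, the expected step from compound 3 to compound 4 in this assay is no change at the digits printed from compound 3 to compound 4 (within the scatter), that is, none beyond the scatter in either direction. Compound 4 is therefore estimated at 10 nM, within a range from 4 nM to 25 nM.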

Compound 4, half-maximal inhibitory concentration: 10 nM
The estimate for compound 4 equals the measured number at the digits printed; the measured number falls inside the stated range.
By their numbers in this assay, from the lowest: compounds 3, 4 and 2 (each within the scatter of the next); then compound 1.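

In this assay, placing a methyl on the amine nitrogen of the piperidin-4-yl group gives no change at the digits printed from compound 3 to compound 4 (within the scatter). Going by these compounds alone, this is the only step in the set that changes a single place, so it gives the first direct reading of this position; compounds 1, 2 and 3 differ from one another in more than one place and could not show how this nitrogen responds to a change. Going from piperidin-4-yl to 1-methylpiperidin-4-yl, far from the shared core, leaves the number within the scatter, but no supporting measurement is available to explain this result.

As far as these compounds go, a single methyl is only the smallest possible addition, so it remains open whether a longer chain such as propyl, or an acetyl group forming an amide at this nitrogen, would also leave the number within the scatter. Also open, from the compounds shown here alone, is what would happen with a cyclohexyl ring in place of the piperidin-4-yl group, which would remove this amine nitrogen altogether.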